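This account rests on a few compounds, and the source may have more. Where it says the series, first, only, none or still open, it means among the compounds named here.

Compound 1 `C=C(Br)C(=O)Nc1ccc(/C=C/C(=O)c2ccc(Br)cc2)cc1`: 680 nM
Compound 2 `Nc1ccc(/C=C/C(=O)c2ccc(Br)cc2)cc1`: 10000 nM

In a functional assay on MOLT-4 cells (Homo sapiens) for antiproliferative activity, with a stated time of 48 h (on this read-out lower numbers stand for stronger inhibition and higher numbers for weaker inhibition), compound 2 has the higher of the two numbers, at 10000 nM. Compound 3 `COc1ccc(C(=O)/C=C/c2ccc(N)cc2)cc1` has methoxy in place of bromo on an aromatic carbon, para to a large group (methoxy in place of bromo on an aromatic carbon). Going by the values given here, the only measured step, a 15-fold higher number from compound 1 to compound 2 (1.17 log units; beyond the scatter), is large, but it concerns the group on the nitrogen, so it gives no direct guide to this exchange. No step beyond the scatter is therefore expected, in either direction. The expected change is a 1.3-fold lower number from compound 2 to compound 3 (0.10 log units; within the scatter). The estimate for compound 3 is 8000 nM, with an expected range from 2500 nM to 25000 nM.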

Compound 3, half-maximal inhibitory concentration: 19000 nM
Compound 3: middle estimate off by 2.4-fold (0.38 log units), on the low side, and the stated range covers the measured number.
By their numbers in this assay, from the lowest: compound 1; then compounds 2 and 3 (each within the scatter of the next).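

In this assay, methoxy in place of bromo on an aromatic carbon, para to a large group, gives a 1.9-fold higher number from compound 2 to compound 3 (0.28 log units; within the scatter). This position therefore accepts the exchange of a bromine atom for a group with one hydrogen-bond acceptor without a change beyond the scatter, at least while the nitrogen carries only hydrogen. No measurement shown explains this result.

Going by these compounds, it remains open whether the same exchange behaves alike with the (1-bromoethenyl)carbonyl group of compound 1 on the nitrogen. On these data alone, how a carboxylic acid or a dimethylamino group would fare at this position also remains open.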